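The compounds below may be only part of what the source reports. "The series", "measured", "known", "first", "only" and "open" are said of these compounds alone.

In an ADME assay on cells (Hepatocyte, Homo sapiens) for metabolic stability, with a stated time of 30 min (on this read-out lower numbers stand for a less stable compound and higher numbers for a more stable compound), compound 1 (`NC1CCC(CN2CCN(c3cc(=O)c4cc(C(F)(F)F)cc([N+](=O)[O-])c4s3)CC2)CC1`) gives 83.6% and compound 2 (`O=c1cc(N2CCN(CC3CCC(NS(=O)(=O)c4ccccc4)CC3)CC2)sc2c([N+](=O)[O-])cc(C(F)(F)F)cc12`) gives 90.8% on the shared core. Compound 3 (`Cc1ccc(C(=O)OC2CCC(CN3CCN(c4cc(=O)c5cc(C(F)(F)F)cc([N+](=O)[O-])c5s4)CC3)CC2)cc1`) gives 9.7% as the lowest of the three numbers, beyond the scatter from both other compounds. The two large steps behind that position (a number 73.9 percentage points lower from compound 1 to compound 3 (beyond the scatter)) and (a number 81.1 percentage points lower from compound 2 to compound 3 (beyond the scatter)) each put ((4-methylphenyl)carbonyl)oxy on the saturated ring carbon in place of a group attached through nitrogen.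

Compound 4 (`CC(=O)NC1CCC(CN2CCN(c3cc(=O)c4cc(C(F)(F)F)cc([N+](=O)[O-])c4s3)CC2)CC1`) is still unmeasured. It carries acetamido in place of ((4-methylphenyl)carbonyl)oxy on a saturated ring carbon and so returns a nitrogen-attached group to that carbon. Substitution on the amine nitrogen of compound 1 shifted the number only within the scatter (a number 7.2 percentage points higher from compound 1 to compound 2 (within the scatter)) in the one case measured. Within the data shown here, no acetamido compound has been measured, so the comparison with compound 1 and compound 2 remains an extrapolation from two examples. A large upward step is therefore expected (a number 72.3 percentage points higher from compound 3 to compound 4 (beyond the scatter)) in this assay on this reasoning. For compound 4 the estimated value is 82% with an expected range from 62% to 95% on this read-out.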

Compound 4, percent of the compound remaining: 86.8%
Compound 4: middle estimate off by 4.8 percentage points, on the low side; low and high end bracket the measured number.
By their numbers in this assay, from the lowest: compound 3; then compounds 1, 4 and 2 (each within the scatter of the next).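

Acetamido on the saturated ring carbon restores the number in this assay (a number 77.1 percentage points higher from compound 3 to compound 4 (beyond the scatter)), and this is the second nitrogen-attached substituent at that position to differ sharply from ((4-methylphenyl)carbonyl)oxy. Acetyl on the amine nitrogen stays within the scatter of both hydrogen (a number 3.2 percentage points higher from compound 1 to compound 4 (within the scatter)) and phenylsulfonyl (a number 4 percentage points lower from compound 2 to compound 4 (within the scatter)), so compounds 1, 2 and 4 form one group across these three substituents, with compound 3 the only one apart from them. A carbonyl in compound 4 and an aromatic ring in compound 2 each occur with a nitrogen attachment without a low number, but the data give no cause for the low number of compound 3.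

In compound 3, the oxygen attachment, the carbonyl and the 4-methylphenyl ring occur together, so the step from compound 3 to compound 4 does not separate their contributions. Acetoxy and ((4-methylphenyl)carbonyl)amino on the same ring carbon would test the oxygen attachment and the aromatic carbonyl separately, while hydroxyl, a simple ether and a longer acyl chain remain open as further substituents at this position.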